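The source may report more compounds than this note shows. Statements on the series, on what has been measured and on what is new or still open speak of the compounds shown alone.

Working notes on the series. Within the data shown here, compound 1, `Cc1ncnc2c1c(I)cn2[C@@H]1O[C@H](CO)[C@@H](O)[C@H]1O`, is the only member with a numeric value in a functional assay on A549 cells (Homo sapiens), read by MTT assay, with a stated time of 72 h; a lower number here means a stronger inhibitor, a higher number a weaker inhibitor: in this assay compound 1 gives 12200 nM. Compound 2, `CSc1ncnc2c1c(-c1ccccc1)cn2[C@@H]1O[C@H](CO)[C@@H](O)[C@H]1O`, gives > 20000 nM in this assay, which is a limit of the assay and not a number. Compound 3, `Cc1nc(N)c2c(-c3ccccc3)cn([C@@H]3O[C@H](CO)[C@@H](O)[C@H]3O)c2n1`, gives > 20000 nM in this assay, again a limit. Compound 1 therefore stands as the single measured inhibitor, the other two values being (the limit of > 20000 nM in this assay, at which 2 of the 3 values shown sit).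

Compound 4, `Cc1ncnc2c1c(-c1ccoc1)cn2[C@@H]1O[C@H](CO)[C@@H](O)[C@H]1O`, is not yet measured. Against compound 1 the change is furan-3-yl in place of iodo on an aromatic carbon. Among the measured compounds shown here, no two measured compounds differ in one place, so no measured step exists for comparison. Compound 2 and compound 3 each carry a further aromatic ring and sit at the limit; compound 1 with iodo gives a number. On that basis the step in this assay is expected to run toward weaker inhibition, probably beyond the scatter. Compound 4 is expected at 25000 nM, within 8000 nM to 60000 nM, an expected step of a 2.0-fold higher number from compound 1 to compound 4 (0.31 log units; beyond the scatter).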

Compound 4, half-maximal inhibitory concentration: > 20000 nM
Compound 4 gave a limit, no number; the forecaster's own chance of this, stated with the estimate: 55%; the middle value does not contradict the limit.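

Among these compounds, at this aromatic carbon, furan-3-yl in place of iodo gives the first single-place comparison that can be read in this assay, with an at least 1.6-fold higher number from compound 1 to compound 4 (0.21 log units; that floor lies within the scatter). The result for compound 4 is a limit and not a number, so this step is only a floor, and the floor alone does not separate compound 4 from compound 1. Compound 1 remains the only member with a numeric value: the limit of > 20000 nM in this assay, at which 3 of the 4 values shown sit.

On these data alone, whether bromo, an amine or a short alkyl chain in place of iodo on this aromatic carbon would give a number in this assay remains open. As far as these compounds go, the true size of the step also remains open, as the limit for compound 4 does not show how much weaker it is.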